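The compounds below may be only part of what the source reports. "The series", "measured", "known", "first", "only" and "open" are said of these compounds alone.

Among the compounds here, compound 1 `C=CC(=O)Nc1cccc(Nc2ncnc3ccc(-c4ccc(Cl)nc4)cc23)c1` and compound 2 `C=CC(=O)Nc1cccc(Oc2ncnc3ccc(-c4ccc(F)nc4)cc23)c1` have been measured in a functional assay on Raji cells (Homo sapiens) for inhibition, read by MTT assay, with a stated time of 48 h; a higher number here means a weaker inhibitor, a lower number a stronger inhibitor. In this assay compound 1 gives 11600 nM, and compound 2 gives 11000 nM. These two numbers lie within the usual scatter of each other, so neither compound is set apart from the other, and both sit at the weak end of what such an assay can show. Compound 3 `C=CC(=O)Nc1cccc(Oc2ncnc3ccc(-c4ccc(Cl)nc4)cc23)c1` was also tested, but in this assay compound 3 is recorded as "not determined" (no result reported), so no single number is available for it and where it stands cannot be said from the data at hand. Compound 4 `C=CC(=O)Nc1cccc(Oc2ncnc3ccc(-c4cnc5ccccc5c4)cc23)c1` has not yet been measured. It differs from compound 3 in one place: quinolin-3-yl in place of 6-chloropyridin-3-yl on an aromatic carbon. For the measured compounds named here, no measured pair here isolates this change, so the size of the step from compound 3 to compound 4 in this assay cannot be read from data. With compound 1 and compound 2 both weak in this assay, the reasonable expectation is a value of the same order, with no clear direction beyond the scatter. Compound 4 is therefore expected to give about 9000 nM in this assay, with a likely range from 2500 nM to 35000 nM.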

Compound 4, half-maximal inhibitory concentration: 8600 nM
Beside the measured number, compound 4's estimate is 1.0-fold (0.02 log units) above it; the measured number falls inside the stated range.
By their numbers in this assay, from the lowest: compounds 4, 2 and 1 (each within the scatter of the next).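

In this assay, for the compounds shown here, the step of a 1.3-fold lower number from compound 2 to compound 4 (0.11 log units; within the scatter) is the first reading of a single change at this aromatic carbon of the shared core, since the earlier compounds offered no measured pair that differed in only one place. Here quinolin-3-yl, which brings a six-membered aromatic ring of carbon only as well as one holding a hetero atom, replaces 6-fluoropyridin-3-yl, and the two compounds cannot be told apart, so this larger fused group sets compound 4 no further from compound 2 than repeat measurements would. Nothing given here accounts for this result.

The step from compound 3 to compound 4 cannot be read, as compound 3 has no number, so the 6-chloropyridin-3-yl group remains unplaced against quinolin-3-yl at this carbon. Going by these compounds, whether a group of a different kind at the same carbon, such as an amine, a carboxylic acid or a longer alkyl chain, would shift the number beyond the scatter remains open.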